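Swapping the aryl group on the ring nitrogen of compound 3

The source may hold more compounds than are shown below. What is called first, only, known or untested is meant among the compounds shown, and "the series" means these compounds.

Of the compounds shown here, three sharing one core have been measured in an assay on HEK-293T cells for displacement of a labelled ligand from corticotropin-releasing factor receptor 1 (Homo sapiens), read by scintillation counting, with a stated time of 2 h; a higher number here means a weaker inhibitor, a lower number a stronger inhibitor. Compound 1 `CCCCN(CC)c1cc(C)nc2c1NC(=O)CN2c1ccc(C(C)(C)C)cc1Br` gives 4.2 nM, compound 2 `CCCN(CCC)c1cc(C)nc2c1NC(=O)CN2c1ccc(C(C)C)cc1Br` gives 3.1 nM, and compound 3 `CCCCN(CC)c1cc(C)nc2c1NC(=O)CN2c1ccc(Br)cc1Cl` gives 2.7 nM. Compound 3 shows the lowest number of the three, yet its gaps to compound 2 and to compound 1 both lie within the scatter, so no order among them can be claimed.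

Compound 4 `CCCCN(CC)c1cc(C)nc2c1NC(=O)CN2c1ccc(OC)cc1C` has not been measured. It differs from compound 3 by 4-methoxy-2-methylphenyl in place of 4-bromo-2-chlorophenyl on a nitrogen on an aromatic ring in a ring. For the measured compounds named here, no step between measured compounds shows what such a swap does here, so the data give no direction for it.

In this assay compound 4 is expected at 5 nM, between 1.5 nM and 20 nM. The step from compound 3 to compound 4 is estimated as a 1.9-fold higher number from compound 3 to compound 4 (0.27 log units; within the scatter), near the scatter, since nothing measured argues otherwise.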

Compound 4, inhibition constant: 4 nM
Compound 4: the middle estimate sits 1.3-fold (0.10 log units) above what was measured, and the stated range covers the measured number.
By their numbers in this assay, from the lowest: compounds 3, 2, 4 and 1 (each within the scatter of the next).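

In this assay, 4-methoxy-2-methylphenyl in place of 4-bromo-2-chlorophenyl on the ring nitrogen gives a 1.5-fold higher number from compound 3 to compound 4 (0.17 log units; within the scatter). This first step read at this position shows that an aryl group with no halogen and one hydrogen-bond acceptor can stand there with the number staying within the scatter of the halogenated one. No measured evidence bears on this result.

From the compounds shown here alone, both substituents on the phenyl ring differ at once, so the share of each remains open. Also open, going by these compounds, is what an amine or a carboxylic acid on that ring would do.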